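The source may hold more compounds than are shown below. What is called first, only, known or untested is meant among the compounds shown, and "the series" means these compounds.

Compound 1 `CCn1c(C(=O)N(CCC#N)CCC#N)ccc1C(CC)(CC)c1ccc(OCCC(O)(CC)CC)c(C)c1` gives 46300 nM in a functional assay on HepG2 cells (Homo sapiens) for antiproliferative activity, read by MTT assay, with a stated time of 48 h; on this read-out higher numbers stand for weaker inhibition and lower numbers for stronger inhibition.
Compound 2 `CCn1c(C(=O)Nc2ccc(OC(F)(F)F)cc2)ccc1C(CC)(CC)c1ccc(OCCC(O)(CC)CC)c(C)c1` gives in this assay only a limit of the assay, > 50000 nM.
Compound 3 `CCn1c(C(=O)N(C)CCO)ccc1C(CC)(CC)c1ccc(OCCC(O)(CC)CC)c(C)c1` gives 510 nM in this assay.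

Among the two measured numbers compound 1 holds the highest; its nearest neighbour is compound 3, reached by a 91-fold lower number from compound 1 to compound 3 (1.96 log units; beyond the scatter). Compound 2 stands at the limit (the limit of > 50000 nM in this assay, at which 1 of the 3 values shown sits). Compound 4 `CCn1c(C(=O)NC(CO)CCO)ccc1C(CC)(CC)c1ccc(OCCC(O)(CC)CC)c(C)c1` arises from compound 1 by a group of 7 heavy atoms (4 carbon, 1 nitrogen, 2 oxygen; no ring) in place of a group of 9 heavy atoms (6 carbon, 3 nitrogen; no ring), on a carbonyl carbon. Within the data shown here, two measured steps bear on this change. The step of an at least 1.0-fold higher number from compound 1 to compound 2 (0.03 log units; that floor lies within the scatter), which put a ring-bearing group on the carbonyl carbon, stayed within the scatter, whereas a 91-fold lower number from compound 1 to compound 3 (1.96 log units; beyond the scatter) brought a large fall when a small group with one oxygen and one nitrogen took the place of the nitrile-bearing group. The entering group of compound 4 resembles that of compound 3 in carrying oxygen and nitrogen without a ring, so a lower number is expected for compound 4, by about a 23-fold lower number from compound 1 to compound 4 (1.36 log units; beyond the scatter), though less surely than the full fall seen for compound 3. The estimate for compound 4 is 2000 nM, with a range from 400 nM to 10000 nM.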

Compound 4, half-maximal inhibitory concentration: 24800 nM
Beside the measured number, compound 4's estimate is 12-fold (1.09 log units) below it, outside the stated range (above it).
By their numbers in this assay, from the lowest: compound 3; then compounds 4 and 1 (each within the scatter of the next). At a limit, above all of these: compound 2.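

Compound 4 did not follow compound 3, although both entering groups carry oxygen and nitrogen without a ring on a carbonyl carbon: in this assay the change from the nitrile-bearing group gave a 1.9-fold lower number from compound 1 to compound 4 (0.27 log units; within the scatter), while the comparison with the smaller group gave a 49-fold higher number from compound 3 to compound 4 (1.69 log units; beyond the scatter). At this position, then, the presence of hydroxyl alone does not secure the large fall seen for compound 3. The comparison with the aryl amide gives only an at least 2.0-fold lower number from compound 2 to compound 4 (0.30 log units; that floor lies within the scatter), which sets no order, and compound 2 remains a limit rather than a number: the limit of > 50000 nM in this assay, at which 1 of the 4 values shown sits.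

The compounds shown leave open whether the gap between compound 3 and compound 4 lies in the methyl on the amide-type nitrogen or in the larger 3-hydroxy-1-(hydroxymethyl)propyl chain. A single 2-hydroxyethyl on that nitrogen, or an amine or carboxylic acid at the end of the chain, would bear on this.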